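A Shared Substitution Moved Onto a Second Core

A few compounds are considered here, and "the series" means these few. Any claim that something is new, unique, unknown or untested is made for them only; others in the source may bear on it.

Compound 1 `Cc1ccc2[nH]c(-c3ccc(-c4ccc(-c5cccc(Cl)c5)cc4)cc3)nc2c1` and compound 2 `COc1ccc(-c2ccc(-c3ccc(-c4nc5cc(C)ccc5[nH]4)cc3)cc2)cc1OC` are built on one core, while compound 3 `Oc1cccc2[nH]c(-c3ccc(-c4ccc(-c5cccc(Cl)c5)cc4)cc3)nc12` and the as yet unmeasured compound 4 `COc1ccc(-c2ccc(-c3ccc(-c4nc5c(O)cccc5[nH]4)cc3)cc2)cc1OC` are built on another. The difference between the two cores is not broken down here.

In a functional assay on COLO 205 cells (Homo sapiens) for inhibition, read by sulforhodamine B assay (on this read-out higher numbers stand for weaker inhibition of growth and lower numbers for stronger inhibition of growth), compound 1 gives 2780 nM, and compound 2 gives 2320 nM. Among the compounds with values here, the only change between these two is 3,4-dimethoxyphenyl in place of 3-chlorophenyl on an aromatic carbon, and it made a step of a 1.2-fold lower number from compound 1 to compound 2 (0.08 log units; within the scatter), so the two numbers cannot be told apart by this kind of measurement.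

In this assay compound 3 gives 8600 nM, the highest of the three measured numbers and beyond the scatter from both compound 1 and compound 2. Compound 4 carries the same change on this second core: 3,4-dimethoxyphenyl in place of 3-chlorophenyl on an aromatic carbon. The surroundings of the place are described in the same words for both pairs, so the change is the same one seen once already.

Because the earlier step of a 1.2-fold lower number from compound 1 to compound 2 (0.08 log units; within the scatter) stayed within the scatter, the expectation is that compound 4 will stay close to compound 3, and the expected step is a 1.2-fold lower number from compound 3 to compound 4 (0.08 log units; within the scatter). On that basis compound 4 is estimated to give 7200 nM in this assay, with an expected range from 3000 nM to 17000 nM.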

Compound 4, concentration for 50% growth inhibition: 1320 nM
For compound 4 the middle estimate is 5.5-fold (0.74 log units) above the measured one; measured number below the stated range.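

In this assay, the swap of 3-chlorophenyl for 3,4-dimethoxyphenyl does not have one fixed size that can be carried from core to core, since the same change did very different things on the two cores: the same change on two cores in this assay, a 1.2-fold lower number (0.08 log units; within the scatter) from compound 1 to compound 2 and a 6.5-fold lower number (0.81 log units; beyond the scatter) from compound 3 to compound 4, 5.4-fold (0.74 log units) apart, beyond the scatter of two such steps. On the second core the change brings a 6.5-fold lower number from compound 3 to compound 4 (0.81 log units; beyond the scatter), while the pair of compounds that carry 3,4-dimethoxyphenyl on different cores shows a 1.8-fold lower number from compound 2 to compound 4 (0.24 log units; within the scatter), so the two cores cannot be told apart when this group is present, even though compound 3 stands apart from compound 1 with the 3-chlorophenyl group. This rests on a single pair of compounds per core, so it shows that the effect of the change depends on the core in these four compounds, but it does not show why, or that other changes in the series would behave in the same way.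

Still open, from the compounds shown here alone, is whether the larger step on the second core needs both methoxy groups or would appear with a single methoxy group, and whether an amine or a carboxylic acid at the same place would also differ between the two cores. Also open, going by these compounds, is whether a third core would follow the first or the second.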